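This account rests on a few compounds, and the source may have more. Where it says the series, first, only, none or still open, it means among the compounds named here.

The series shares one core, seen in compound 1 `Cc1cc(Oc2ccc(-c3ccn4c(CC5CC5)nnc4c3C(F)(F)F)cc2F)ccn1` and compound 2 `CC(C)Nc1ccc(-c2ccn3c(CC4CC4)nnc3c2C(F)(F)F)cc1Cl`. In an assay on cells for displacement of a labelled ligand from metabotropic glutamate receptor 2 (Homo sapiens), read by scintillation counting, with a stated time of 60 min (on this read-out lower numbers stand for stronger inhibition and higher numbers for weaker inhibition), compound 1 gives 7.08 nM, and compound 2 gives 3.89 nM. Among the compounds with values here, compound 2 thus carries the lowest of the two numbers measured so far, yet its nearest neighbour, compound 1, lies within the scatter of it, so no order between the two can be read. Compound 3 `O[C@H]1CC[C@H](Oc2ccc(-c3ccn4c(CC5CC5)nnc4c3C(F)(F)F)cc2Cl)CC1` has not yet been measured. It differs from compound 2 in one place: (4-hydroxycyclohexyl)oxy in place of isopropylamino on an aromatic carbon, on an aromatic carbon ortho to a chloro group and para to a large group. Within the data shown here, no step between measured compounds covers an exchange of this kind, and the two measured compounds sit within the scatter of each other. Compound 3 is therefore expected to stay close, with a step of a 2.6-fold higher number from compound 2 to compound 3 (0.41 log units; beyond the scatter) toward a somewhat higher number, near the edge of the scatter. The estimate for compound 3 in this assay is 10 nM, within a range from 3 nM to 40 nM.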

Compound 3, inhibition constant: 1.91 nM
Estimate against measurement, compound 3: 5.2-fold (0.72 log units) above; the measured number lies below the stated range.
By their numbers in this assay, from the lowest: compound 3; then compounds 2 and 1 (each within the scatter of the next).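

On an aromatic carbon ortho to a chloro group and para to a large group, the exchange of isopropylamino for (4-hydroxycyclohexyl)oxy gives, in this assay, a 2.0-fold lower number from compound 2 to compound 3 (0.31 log units; beyond the scatter), a modest step. Within the data shown here, it shows that this position accepts a group of 8 heavy atoms with a six-membered non-aromatic ring in place of one of 4 heavy atoms with no ring, and that the number falls rather than rises, which the earlier pair, joined by no single-place step, could not show. Nothing measured here accounts for the step.

On these data alone, whether the hydroxyl matters stays open, as a plain cyclohexyloxy group would be needed to tell. So does whether the ether oxygen matters, which a cyclohexylamino group would address, and how the other stereoisomer of (4-hydroxycyclohexyl)oxy would compare.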